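Amide variation on a shared core: furan in place of difluorophenyl

The compounds below may be only part of what the source reports. "The series", "measured", "known", "first", "only" and "open" are said of these compounds alone.

Measured compounds:
compound 1, `CCCC(=O)Nc1ccc(N2CCN(c3ccc(OC[C@@H]4CO[C@@](Cn5cncn5)(c5ccc(Cl)cc5Cl)O4)cc3)CC2)cc1`, 2990 nM
compound 2, `O=C(Nc1ccc(N2CCN(c3ccc(OC[C@@H]4CO[C@@](Cn5cncn5)(c5ccc(Cl)cc5Cl)O4)cc3)CC2)cc1)c1cccc(F)c1`, 6640 nM
compound 3, `O=C(Nc1ccc(N2CCN(c3ccc(OC[C@@H]4CO[C@@](Cn5cncn5)(c5ccc(Cl)cc5Cl)O4)cc3)CC2)cc1)c1ccc(F)c(F)c1`, 8690 nM

In a functional assay on A549 cells (Homo sapiens) for inhibition, read by MTT assay, with a stated time of 48 h (a lower number here means a stronger inhibitor, a higher number a weaker inhibitor), compound 3 gives the highest of the three numbers. Its nearest neighbour is compound 2, and a 1.3-fold higher number from compound 2 to compound 3 (0.12 log units; within the scatter), so the two cannot be told apart. The larger gap is to compound 1: a 2.9-fold higher number from compound 1 to compound 3 (0.46 log units; beyond the scatter).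

Compound 4, `Cc1ccc(C(=O)Nc2ccc(N3CCN(c4ccc(OC[C@@H]5CO[C@@](Cn6cncn6)(c6ccc(Cl)cc6Cl)O5)cc4)CC3)cc2)o1`, differs from compound 3 in one place: 5-methylfuran-2-yl in place of 3,4-difluorophenyl on a carbonyl carbon. For the measured compounds named here, no measured step swaps one aromatic group for another on this carbonyl carbon; the steps that come closest are a 2.2-fold higher number from compound 1 to compound 2 (0.35 log units; beyond the scatter) and a 2.9-fold higher number from compound 1 to compound 3 (0.46 log units; beyond the scatter), both modest moves from an alkyl to an aryl amide, and a 1.3-fold higher number from compound 2 to compound 3 (0.12 log units; within the scatter), which changes nothing beyond the scatter. A five-membered aromatic ring on the carbonyl is therefore expected to land near the aryl amides, perhaps a little toward compound 1, so the expected step is a 1.4-fold lower number from compound 3 to compound 4 (0.16 log units; within the scatter), likely within the scatter. For compound 4 the estimated value in this assay is 6000 nM, with a range from 2500 nM to 15000 nM.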

Compound 4, half-maximal inhibitory concentration: 4750 nM
Beside the measured number, compound 4's estimate is 1.3-fold (0.10 log units) above it, within the range that was stated.
By their numbers in this assay, from the lowest: compounds 1, 4, 2 and 3 (each within the scatter of the next, the first and the last beyond it).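

In this assay, for the compounds shown here, this is the first exchange of one aromatic group for another on the carbonyl carbon, and it gives no readable shift, either from the 3,4-difluorophenyl amide (a 1.8-fold lower number from compound 3 to compound 4 (0.26 log units; within the scatter)) or from the 3-fluorophenyl amide (a 1.4-fold lower number from compound 2 to compound 4 (0.15 log units; within the scatter)). Going by these compounds alone, the 5-methylfuran-2-yl amide also stays within the scatter of the propyl amide (a 1.6-fold higher number from compound 1 to compound 4 (0.20 log units; within the scatter)), whereas the 3,4-difluorophenyl amide lies beyond it (a 2.9-fold higher number from compound 1 to compound 3 (0.46 log units; beyond the scatter)), so compound 4 blurs the alkyl-to-aryl separation that the earlier compounds suggested. Nothing available explains these numbers.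

The compounds shown leave open whether a furan-2-yl group without the methyl, or a thiophene or pyridine ring, on this carbonyl carbon would differ beyond the scatter. They also leave open what a longer alkyl chain or an amine-bearing chain would do here.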